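Removing the fluoro from the inactive compound 1

The source may report more compounds than this note shows. Statements on the series, on what has been measured and on what is new or still open speak of the compounds shown alone.

Compound 1 `COc1cc(-c2ncnn2-c2cccc(F)c2)cc(OC)c1OC` reads > 10000 nM in a functional assay on A549 cells (Homo sapiens) for antiproliferative activity, read by MTT assay, with a stated time of 72 h (a lower number here means a stronger inhibitor, a higher number a weaker inhibitor), which is a limit of the assay and not a number. Compound 2 `COc1cc(-n2ncnc2-c2ccc(Cl)cc2)cc(OC)c1OC` reads > 10000 nM in this assay, and this too is a limit. Among the measured compounds shown here, compound 1 therefore stands with the only other compound, at the limit of > 10000 nM in this assay, at which 2 of the 2 values shown sit. No measured value gives its position more exactly.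

Compound 3 `COc1cc(-c2ncnn2-c2ccccc2)cc(OC)c1OC` is still to be measured. It differs from compound 1 by hydrogen in place of fluoro on an aromatic carbon, the change from 3-fluorophenyl to phenyl: hydrogen in place of fluoro on an aromatic carbon.

For the measured compounds named here, no two measured compounds differ in one place only, so the series offers no measured step size for comparison. The expected step in this assay is a number no higher from compound 1 to compound 3 (the limit leaves the size open), which means no change beyond the scatter in either direction. This expectation rests on compound 1 at > 10000 nM, a limit. For compound 3 the estimated value is 10000 nM, with an expected range from 3000 nM to 30000 nM, and the assay is expected most likely to report only a limit.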

Compound 3, half-maximal inhibitory concentration: > 10000 nM
Compound 3 ended at the assay's limit (the forecaster's own chance of this, stated with the estimate: 70%); the middle value lies on the limit itself.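

Compound 3 and compound 1 both read as limits in this assay and not as numbers, so the step between compound 1 and compound 3 cannot be read. The compounds shown leave open whether any change to the shared core, fluoro to hydrogen included, moves antiproliferative activity at all, and by how much: the limit of > 10000 nM in this assay, at which 3 of the 3 values shown sit.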